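From 2-bromobenzyl to allyl on the sulfur

This account rests on a few compounds, and the source may have more. Where it says the series, first, only, none or still open, it means among the compounds named here.

In an ADME assay on GES1 cells (Homo sapiens) for inhibition, read by MTT assay, with a stated time of 72 h (a higher number here means a weaker inhibitor, a lower number a stronger inhibitor), compound 1 (`Cc1cc(Nc2cc(-c3ccccc3)[nH]n2)n2nc(SCCc3ccccc3)nc2n1`) gives 37400 nM as its value, compound 2 (`Cc1cc(Nc2cc(-c3ccccc3)[nH]n2)n2nc(SCc3c(Cl)cccc3Cl)nc2n1`) gives 39600 nM and compound 3 (`Cc1cc(Nc2cc(-c3ccccc3)[nH]n2)n2nc(SCc3ccccc3Br)nc2n1`) gives 41100 nM as well. Compound 3 therefore stands level with the other two. The measured steps that bear on the next change are a 1.1-fold higher number from compound 1 to compound 3 (0.04 log units; within the scatter) and a 1.0-fold higher number from compound 2 to compound 3 (0.02 log units; within the scatter) and also a 1.1-fold higher number from compound 1 to compound 2 (0.02 log units; within the scatter) and all of them stay within the scatter. Compound 4 (`C=CCSc1nc2nc(C)cc(Nc3cc(-c4ccccc4)[nH]n3)n2n1`) differs from compound 3 by vinyl in place of 2-bromophenyl on a saturated chain carbon bound to a sulfur with vinyl in place of 2-bromophenyl on a saturated chain carbon bound to a sulfur. The measured steps only exchange one aromatic group for another, and none removes the ring, so they guide this change only loosely. Even so, no step beyond the scatter is expected in this assay here. The expected step is a 1.2-fold higher number from compound 3 to compound 4 (0.07 log units; within the scatter) and no more than that. For compound 4 the estimated value is 48000 nM with an expected range from 24000 nM to 95000 nM as its limits.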

Compound 4, half-maximal inhibitory concentration: > 50000 nM
Compound 4 gave a limit, no number; the forecaster's own chance of this, stated with the estimate: 15%; middle value at least 1.0-fold (0.01 log units) from the limit.
By their numbers in this assay, from the lowest: compounds 1, 2 and 3 (each within the scatter of the next). At a limit, above all of these: compound 4.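

The reading for compound 4 is a limit and not a number: the limit of > 50000 nM in this assay, at which 1 of the 4 values shown sits. Only floors can be read from it: an at least 1.2-fold higher number from compound 3 to compound 4 (0.08 log units; that floor lies within the scatter), an at least 1.2-fold higher number from compound 2 to compound 4 (0.10 log units; that floor lies within the scatter) and an at least 1.3-fold higher number from compound 1 to compound 4 (0.12 log units; that floor lies within the scatter), so a real difference from any of the three aryl-bearing compounds is neither shown nor excluded. For the compounds shown here, still, this is the first change at this position that removes the aromatic ring, and replacing 2-bromobenzyl with allyl gives no stronger inhibitor in this assay.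

On these data alone, how far the number for compound 4 lies from the others remains open, so the size of this step is unknown. Also open, as far as these compounds go, is how this assay would read with an amine, a carboxylic acid or a longer chain at this place.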